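Swapping a Hydroxy for a Methyl on the Side Chain

This account rests on a few compounds, and the source may have more. Where it says the series, first, only, none or still open, it means among the compounds named here.

Of the compounds shown here, three sharing one core have been tested in a functional assay on U-266 cells (Homo sapiens) for antiproliferative activity, read by MTT assay, with a stated time of 72 h; a higher number here means a weaker inhibitor, a lower number a stronger inhibitor. Compound 1, `C[C@H](NC(=O)/C(C#N)=C/c1cccc(Br)n1)c1ccc(Br)cc1`, gives 1800 nM. Compound 2, `N#C/C(=C\c1cccc(Br)n1)C(=O)N[C@@H]1CCc2ccccc21`, gives 2500 nM. Compound 3, `N#C/C(=C\c1cccc(Br)n1)C(=O)N[C@@H](CO)c1ccccc1`, gives 3500 nM, the highest of the three numbers, though its gaps to compound 2 and to compound 1 both fall inside the usual scatter of repeated measurements, so no real ordering among them can be claimed.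

Compound 4, `CC[C@H](NC(=O)/C(C#N)=C/c1cccc(Br)n1)c1ccccc1`, is the next compound to be measured. The change is methyl in place of hydroxy on a saturated chain carbon, two bonds along the chain from an amide-type nitrogen and an aromatic carbon; put another way, a hydroxymethyl becomes an ethyl. Compound 1 also carries a methyl on that carbon and gives 1800 nM, which sits within the scatter of compound 3. On that basis the step from compound 3 to compound 4 in this assay is expected to be small and slightly downward, a 1.8-fold lower number from compound 3 to compound 4 (0.24 log units; within the scatter), staying within the scatter. Compound 4 is therefore estimated at 2000 nM, with a range from 900 nM to 4500 nM.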

Compound 4, half-maximal inhibitory concentration: 1400 nM
Compound 4: the middle estimate sits 1.4-fold (0.15 log units) above what was measured, and the stated range covers the measured number.
By their numbers in this assay, from the lowest: compounds 4, 1, 2 and 3 (each within the scatter of the next, the first and the last beyond it).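

For the compounds shown here, compound 3 and compound 4 form the first pair here that differs in only one place, so the effect of a single change can finally be read. In this assay, methyl in place of hydroxy on this saturated chain carbon gives a 2.5-fold lower number from compound 3 to compound 4 (0.40 log units; beyond the scatter), a modest step. In this pair, the hydroxy, with the hydrogen-bond donor and acceptor counted for it, is therefore not required for activity, and the ethyl side chain gives the lower number; no measurement here explains why.

As far as these compounds go, it remains open what an amine, a carboxylic acid or a longer chain such as propyl would give on this same carbon. From the compounds shown here alone, it is also open whether the swap from hydroxymethyl to ethyl would give a similar step with a different aromatic group on that carbon.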